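The compounds below may be only part of what the source reports. "The series", "measured", "known", "first", "only" and "open" are said of these compounds alone.

Measured so far:
compound 1 `COc1cc(/C=C/C(=O)c2cc3ccc(O)cc3oc2=O)cc(OC)c1OC` — 8800 nM
compound 2 `COc1cc(/C=C/C(=O)c2cc3cc(OCc4ccccc4)ccc3oc2=O)cc(OC)c1OC` — 26500 nM
compound 3 `COc1cccc(COc2ccc3cc(C(=O)/C=C/c4ccccc4)c(=O)oc3c2)c1` — 33700 nM

In a functional assay on MCF7 cells (Homo sapiens) for cytotoxicity, read by MTT assay, with a stated time of 72 h (a higher number here means a weaker inhibitor, a lower number a stronger inhibitor), compound 2 gives 26500 nM, the second highest of the three numbers. Compound 3 lies within the usual scatter of compound 2, while compound 1 sits beyond the scatter with the lower number. Within the data shown here, no single-change step between measured compounds is available, so the effect of the change at hand has to be judged from the spread of these values alone.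

Compound 4 `COc1cc(/C=C/C(=O)c2cc3cc(O)ccc3oc2=O)cc(OC)c1OC` differs from compound 2 in one place: hydrogen in place of benzyl on an oxygen on an aromatic ring. In this assay compound 4 is expected to give a modestly lower number, a step of about a 1.9-fold lower number from compound 2 to compound 4 (0.28 log units; within the scatter), since compound 1 with its free hydroxy shows 8800 nM. Compound 4 is thus estimated at 14000 nM, with a range from 5000 nM to 40000 nM.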

Compound 4, half-maximal inhibitory concentration: 10900 nM
Estimate against measurement, compound 4: 1.3-fold (0.11 log units) above; measured number inside the range.
By their numbers in this assay, from the lowest: compounds 1 and 4 (each within the scatter of the next); then compounds 2 and 3 (each within the scatter of the next).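

In this assay, among these compounds, the change from benzyloxy to hydroxy gives a 2.4-fold lower number from compound 2 to compound 4 (0.39 log units; beyond the scatter) as the first single-change step. It shows that, at this position, the benzyl group is not needed for the activity seen, and that removing it brings a modest gain. Nothing measured here accounts for this step. The compounds shown leave open how a methyl, a longer chain or an amine-bearing chain on this oxygen would read, so it cannot be told whether the gain requires the free hydroxy or only the absence of benzyl.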